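Adding a second chloro to compound 2

The compounds below may be only part of what the source reports. "The series", "measured", "known", "first", "only" and "open" are said of these compounds alone.

Compound 1 (`CC(C)=CCOc1ccc2c(c1)OC(c1ccc(Cl)cc1Cl)CC2=O`) gives 5260 nM
Compound 2 (`CC(C)=CCOc1cc(O)c2c(c1)OC(c1ccccc1Cl)CC2=O`) gives 4270 nM

In a functional assay (a lower number here means a stronger inhibitor, a higher number a weaker inhibitor), compound 2 lies within the usual scatter of compound 1, so neither can be ranked ahead of the other. Going from compound 2 to compound 3 (`CC(C)=CCOc1cc(O)c2c(c1)OC(c1ccc(Cl)cc1Cl)CC2=O`) brings one change (chloro in place of hydrogen on an aromatic carbon): chloro in place of hydrogen on an aromatic carbon, so 2-chlorophenyl becomes 2,4-dichlorophenyl. Going by the values given here, no measured pair shows this change alone, so the data offer no direction for it, and no shift beyond the scatter is expected. The expected step (a 1.2-fold lower number from compound 2 to compound 3 (0.09 log units; within the scatter)) is therefore small. The estimated value for compound 3 is 3500 nM (range 1300 nM to 9000 nM).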

Compound 3, half-maximal inhibitory concentration: 3340 nM
For compound 3 the middle estimate is 1.0-fold (0.02 log units) above the measured one; the range from low to high includes it.
By their numbers in this assay, from the lowest: compounds 3, 2 and 1 (each within the scatter of the next).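

In this assay, a chloro on the aromatic ring, para to a large group, leaves the two compounds within the usual scatter (a 1.3-fold lower number from compound 2 to compound 3 (0.11 log units; within the scatter)), so 2-chlorophenyl and 2,4-dichlorophenyl cannot be ranked here. Going by these compounds alone, compound 3 also gives the first single-change comparison for the hydroxy on the shared core, and that step too lies within the scatter (a 1.6-fold lower number from compound 1 to compound 3 (0.20 log units; within the scatter)). Nothing available explains either result. On these data alone, whether a methoxy or a phenyl ring in place of this chloro, or an amine in place of the hydroxy, would move the number beyond the scatter remains open.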